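This account rests on a few compounds, and the source may have more. Where it says the series, first, only, none or still open, it means among the compounds named here.

Measured in an ADME assay on microsomes from liver (Homo sapiens) for metabolic stability, read by LC-MS, using NADPH, with stated times of 5 min and 30 min, tested at 1 uM; on this read-out lower numbers stand for slow clearance and higher numbers for fast clearance:
- compound 1 `O=C1c2ccccc2CN1c1cnc(NCc2c(F)ccc3c2CCO3)n2cnnc12`: 13 mL.min-1.g-1
- compound 2 `CN(c1ccn(C)n1)c1cnc(NCc2c(F)ccc3c2CCO3)n2cnnc12`: 11 mL.min-1.g-1
- compound 3 `CN(C(=O)c1ccccc1)c1cnc(NCc2c(F)ccc3c2CCO3)n2cnnc12`: > 300 mL.min-1.g-1 (a limit of the assay)

Compound 3 has no number, only (the limit of > 300 mL.min-1.g-1 in this assay, at which 1 of the 3 values shown sits). In compound 4 `CN(c1cccnc1)c1cnc(NCc2c(F)ccc3c2CCO3)n2cnnc12`, pyridin-3-yl takes the place of benzoyl on a nitrogen on an aromatic ring: pyridin-3-yl in place of benzoyl on a nitrogen on an aromatic ring.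

The closest measured change is at the same nitrogen: an at least 27-fold higher number from compound 2 to compound 3 (1.43 log units; beyond the scatter). The other large change is an at least 23-fold higher number from compound 1 to compound 3 (1.36 log units; beyond the scatter), whereas a 1.2-fold lower number from compound 1 to compound 2 (0.07 log units; within the scatter). A large fall in this assay is therefore expected, on the reasoning that the reverse of an at least 27-fold higher number from compound 2 to compound 3 (1.43 log units; beyond the scatter) should apply here. The expected change is an at least 15-fold lower number from compound 3 to compound 4 (1.17 log units; beyond the scatter). For compound 4 the estimate is 20 mL.min-1.g-1, with an expected range of 8 mL.min-1.g-1 to 70 mL.min-1.g-1.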

Compound 4, intrinsic clearance in microsomes: 80 mL.min-1.g-1
For compound 4 the middle estimate is 4.0-fold (0.60 log units) below the measured one, outside the stated range (above it).
By their numbers in this assay, from the lowest: compounds 2 and 1 (each within the scatter of the next); then compound 4. At a limit, above all of these: compound 3.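

In this assay, pyridin-3-yl in place of benzoyl gives an at least 3.7-fold lower number from compound 3 to compound 4 (0.57 log units; beyond the scatter), a step that rests on a limit for compound 3: the limit of > 300 mL.min-1.g-1 in this assay, at which 1 of the 4 values shown sits.

Losing the benzoyl does not by itself bring the number down to the lowest ones, so the group on this nitrogen still matters among non-benzoyl compounds: pyridin-3-yl in place of 1-methyl-1H-pyrazol-3-yl gives a 7.3-fold higher number from compound 2 to compound 4 (0.86 log units; beyond the scatter). The group of compound 1 also reads lower, with a 6.2-fold higher number from compound 1 to compound 4 (0.79 log units; beyond the scatter).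

Open, as far as these compounds go, is how plain phenyl on this nitrogen would read, which would separate the ring nitrogen of pyridin-3-yl from the ring itself. From the compounds shown here alone, a longer chain in place of the methyl is equally open.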